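Ethyl Ester Change on an Unmeasured Cytotoxicity Partner

This account rests on a few compounds, and the source may have more. Where it says the series, first, only, none or still open, it means among the compounds named here.

Compound 1 `CC(C)N(Cc1cccc(OCCCCCC(=O)O)c1)C(=O)c1ccc(-c2cccc(Oc3ccccc3)c2)cc1` and compound 2 `CC(C)N(Cc1cccc(OCCCCCC(=O)O)c1)C(=O)c1ccc(-c2cc3ccccc3n2S(=O)(=O)c2ccccc2)cc1` are built alike in much of their make-up, but the difference between the two cores is not broken down here. Compound 3 `CCOC(=O)CCCCCOc1cccc(CN(C(=O)c2ccc(-c3cccc(Oc4ccccc4)c3)cc2)C(C)C)c1` differs from compound 1 by ethyl in place of hydrogen on an oxygen next to a carbonyl group. Compound 4 `CCOC(=O)CCCCCOc1cccc(CN(C(=O)c2ccc(-c3cc4ccccc4n3S(=O)(=O)c3ccccc3)cc2)C(C)C)c1`, not yet measured, carries the same change relative to compound 2, (ethyl in place of hydrogen on an oxygen next to a carbonyl group). In an ADME assay on HepG2 cells (Homo sapiens) for cytotoxicity, read by CellTiter-Glo and resazurin assay, with a stated time of 72 h (a higher number here means that more compound is needed for the effect, a lower number that less compound is needed), compound 1 reaches only a limit of the assay, > 18700 nM. In this assay compound 2 likewise gives only a limit, > 26000 nM. Compound 3 also stops at a limit in this assay, > 26000 nM. The two limits leave the step that the two limits leave unreadable from compound 1 to compound 3 without a readable size. Every value shown sits at a limit, the limit of > 18700 nM in this assay, at which 1 of the 3 values shown sits, and (the limit of > 26000 nM in this assay, at which 2 of the 3 values shown sit). Compound 4 is therefore expected to give 40000 nM in this assay. The expected step that the limit leaves unreadable from compound 2 to compound 4 is likewise expected to stay hidden behind the limit.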

Compound 4, half-maximal effective concentration: > 26000 nM
Compound 4 gave a limit, no number; the forecaster's own chance of this, stated with the estimate: 85%; the middle value does not contradict the limit.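

No new step can be read between compound 2 and compound 4, as both stop at a limit in this assay. Whether carboxy to ethoxycarbonyl changes cytotoxicity on either core stays open, with no compound shown giving a number.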